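Chain variation at the shared core: expectation for compound 3

The compounds below may be only part of what the source reports. "The series", "measured", "known", "first", "only" and "open" are said of these compounds alone.

Measured so far in an assay on microsomes from liver for inhibition of sterol O-acyltransferase 1 (Rattus norvegicus); on this read-out higher numbers stand for weaker inhibition and lower numbers for stronger inhibition:
compound 1 `CCCCCCOc1cc(-c2ccccc2)c(-c2ccccc2)nn1`: 72000 nM
compound 2 `CCCCCCC[S+]([O-])c1cc(-c2ccccc2)c(-c2ccccc2)nn1`: 77000 nM

Compound 2 gives the highest of the two numbers in this assay, its nearest neighbour being compound 1, with the step of a 1.1-fold higher number from compound 1 to compound 2 (0.03 log units; within the scatter). Both compounds therefore sit at the weak end, indistinguishable within the scatter.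

Compound 3 `O=C(O)CCCCCSc1cc(-c2ccccc2)c(-c2ccccc2)nn1` differs from compound 2 in one place: a group of 9 heavy atoms (6 carbon, 2 oxygen, 1 sulfur; no ring) in place of a group of 9 heavy atoms (7 carbon, 1 oxygen, 1 sulfur; no ring), on an aromatic carbon. Among the compounds with values here, the only measured step, a 1.1-fold higher number from compound 1 to compound 2 (0.03 log units; within the scatter), exchanged one chain for another on the same aromatic carbon and left the number unchanged beyond the scatter. Within the data shown here, no measured step introduces a carboxylic acid, so the bearing of that part of the change is unknown and the range is kept wide.

Compound 3 is therefore expected to remain near compound 2, a step of a 1.2-fold lower number from compound 2 to compound 3 (0.07 log units; within the scatter), giving an estimated 65000 nM with a range from 15000 nM to 250000 nM.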

Compound 3, half-maximal inhibitory concentration: > 300000 nM
Compound 3 gave a limit, no number; the forecaster's own chance of this, stated with the estimate: 25%; middle value at least 4.6-fold (0.66 log units) away from the limit.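

In this assay, this position on the aromatic carbon responds to the chain it carries: (5-carboxypentyl)sulfanyl gives an at least 3.8-fold higher number from compound 2 to compound 3 (0.59 log units; beyond the scatter), and in place of hexyloxy it gives an at least 4.1-fold higher number from compound 1 to compound 3 (0.61 log units; beyond the scatter). Both steps run towards weaker inhibition, whereas the earlier chain exchange, a 1.1-fold higher number from compound 1 to compound 2 (0.03 log units; within the scatter), did not separate its two compounds. Compound 3 gives a limit and not a number: the limit of > 300000 nM in this assay, at which 1 of the 3 values shown sits.

The compounds shown do not separate the terminal carboxylic acid from the change in the link to the aromatic carbon, as the two differ together in each step to compound 3. From the compounds shown here alone, whether a plain heptylsulfanyl chain, a terminal amine or a longer chain would hold this level or move inhibition away from the weak end remains open.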